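Adding a Cyano Group to Compound 2

A few compounds are considered here, and "the series" means these few. Any claim that something is new, unique, unknown or untested is made for them only; others in the source may bear on it.

Of the compounds shown here, two sharing one core have so far been measured in a functional assay on MDA-MB-231 cells (Homo sapiens) for antiproliferative activity, read by MTT assay, with a stated time of 72 h; on this read-out higher numbers stand for weaker inhibition and lower numbers for stronger inhibition. Compound 1 `Cc1ccc(NC(=O)CCc2cccc3c2B(O)OC3)cc1` gives 1100 nM in this assay. Compound 2 `O=C(CCc1cccc2c1B(O)OC2)Nc1cccc(-c2ccccc2)c1` gives 220 nM, the lowest of the two numbers, and compound 1 stands above it by a gap beyond the usual scatter.

Compound 3 `N#Cc1cccc(-c2cccc(NC(=O)CCc3cccc4c3B(O)OC4)c2)c1` has not yet been measured. It differs from compound 2 in one place: cyano in place of hydrogen on an aromatic carbon. Cut one bond further out, the change reads phenyl to 3-cyanophenyl, the cyano sitting meta to a large group. Going by the values given here, no pair of measured compounds shows what such a change does on this core, so the expected step in this assay is none beyond the scatter, in either direction. Compound 3 is estimated at 250 nM, with a range from 100 nM to 600 nM. This estimate means an expected step of a 1.1-fold higher number from compound 2 to compound 3 (0.06 log units; within the scatter).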

Compound 3, half-maximal inhibitory concentration: 110 nM
For compound 3 the middle estimate is 2.3-fold (0.36 log units) above the measured one, and the stated range covers the measured number.
By their numbers in this assay, from the lowest: compounds 3 and 2 (each within the scatter of the next); then compound 1.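

Putting cyano in place of hydrogen on an aromatic carbon, meta to a large group, gives a 2.0-fold lower number from compound 2 to compound 3 (0.30 log units; within the scatter) in this assay. Going by these compounds alone, this is the first look at this position on the shared core: it accepts a cyano group, with its 2 heavy atoms and triple bond, and the change from phenyl to 3-cyanophenyl brings no difference beyond the usual scatter of repeated measurements. Nothing shown here bears on how the cyano group acts at this position, so the result comes without an explanation.

Going by these compounds, whether an amine or a carboxylic acid at this same position would give a step beyond the scatter remains open. So does whether a cyano group on another carbon of this ring would behave as it does here.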